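Compound 2 to compound 3: one group exchanged

A few compounds are considered here, and "the series" means these few. Any claim that something is new, unique, unknown or untested is made for them only; others in the source may bear on it.

Measured in an ADME assay on Caco-2 cells (Homo sapiens) for permeability, in the apical to basolateral direction, at pH 7.4; a higher number here means that the compound crosses the layer faster, a lower number that the compound crosses the layer more slowly:
- Compound 1 `O=C(N[C@H]1CN(S(=O)(=O)c2ccccc2)C[C@@H]1C(=O)N[C@H]1CCCNC1)c1cc(C2CC2)n[nH]1`: 0.39 10^-6 cm/s
- Compound 2 `O=C(N[C@H]1CN(S(=O)(=O)c2ccccc2)C[C@@H]1C(=O)N[C@H]1CCCNC1)c1nnc(-c2ccc(F)cc2)s1`: < 0.03 10^-6 cm/s, a limit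

Compound 2 stands at the limit of < 0.03 10^-6 cm/s in this assay, at which 1 of the 2 values shown sits. Compound 3 `O=C(N[C@H]1CN(S(=O)(=O)c2ccccc2)C[C@@H]1C(=O)N[C@H]1CCCNC1)c1cc(-c2ccc(Cl)cc2)on1` carries 5-(4-chlorophenyl)-1,2-oxazol-3-yl on a carbonyl carbon: a group of 12 heavy atoms (9 carbon, 1 nitrogen, 1 oxygen, 1 chlorine; one five-membered aromatic ring with 2 hetero atoms, one six-membered aromatic ring of carbon only) in place of a group of 12 heavy atoms (8 carbon, 2 nitrogen, 1 fluorine, 1 sulfur; one five-membered aromatic ring with 3 hetero atoms, one six-membered aromatic ring of carbon only), on a carbonyl carbon. Going by the values given here, the only measured step that bears on this change is an at least 13-fold lower number from compound 1 to compound 2 (1.11 log units; beyond the scatter), a large step at the same place. There, the group grew, whereas here the count of heavy atoms stays equal, so no step beyond the scatter is expected in this assay. The expected step is an at least 1.6-fold higher number from compound 2 to compound 3 (0.22 log units; that floor lies within the scatter). The estimate for compound 3 is 0.05 10^-6 cm/s, with an expected range of 0.02 10^-6 cm/s to 0.2 10^-6 cm/s.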

Compound 3, apparent permeability: < 0.01 10^-6 cm/s
Compound 3 ended at the assay's limit; the forecaster's own chance of this, stated with the estimate: 50%; at least 5.0-fold (0.69 log units) between middle value and limit.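

In this assay, 5-(4-chlorophenyl)-1,2-oxazol-3-yl in place of 3-cyclopropyl-1H-pyrazol-5-yl gives an at least 39-fold lower number from compound 1 to compound 3 (1.59 log units; beyond the scatter), so a large step at this place on the carbonyl carbon is not confined to the group of compound 2. Compound 2 and compound 3 both end at limits of the assay, and the step between them cannot be read. Which part of the entering group goes with the step stays open: 5-cyclopropyl-1,2-oxazol-3-yl at the same place would separate the 1,2-oxazole ring from the 4-chlorophenyl.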